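This account rests on a few compounds, and the source may have more. Where it says the series, first, only, none or still open, it means among the compounds named here.

In a functional assay on MCF7 cells (Homo sapiens) for inhibition, read by MTT assay, with a stated time of 24 h (on this read-out lower numbers stand for stronger inhibition of growth and higher numbers for weaker inhibition of growth), compound 1 (`COc1ccc(C(=O)n2c(-c3cn(C)c4ccccc34)nc3ccccc32)cc1OC`) gives 10200 nM and compound 2 (`COc1cc(C(=O)n2c(-c3cn(C)c4ccccc34)nc3ccccc32)cc(OC)c1OC`) gives 5400 nM. Going by the values given here, these are the only two numbers so far, and they lie within the scatter of each other, so compound 2 stands level with compound 1. Compound 3 (`COc1cc(C(=O)n2c(-c3cn(C)c4ccc(Br)cc34)nc3ccccc32)cc(OC)c1OC`) departs from compound 2 in one place, bromo in place of hydrogen on an aromatic carbon, turning 1-methyl-1H-indol-3-yl into 5-bromo-1-methyl-1H-indol-3-yl. Among the compounds with values here, the one measured step, a 1.9-fold lower number from compound 1 to compound 2 (0.28 log units; within the scatter), concerns a methoxy in place of hydrogen, not a bromo, and it stays small. It offers only weak guidance, and no shift beyond the scatter is expected in this assay. The expected change is a 1.2-fold lower number from compound 2 to compound 3 (0.08 log units; within the scatter). For compound 3 the estimated value is 4500 nM, with an expected range from 1500 nM to 12000 nM.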

Compound 3, concentration for 50% growth inhibition: 9700 nM
Beside the measured number, compound 3's estimate is 2.2-fold (0.33 log units) below it, and the stated range covers the measured number.
By their numbers in this assay, from the lowest: compounds 2, 3 and 1 (each within the scatter of the next).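

Compound 3 is the first of the compounds shown to carry a change on the 1-methyl-1H-indol-3-yl group rather than in the methoxy groups. In this assay, the bromo substitution gives a 1.8-fold higher number from compound 2 to compound 3 (0.25 log units; within the scatter), so compound 2 and compound 3 stand level, and a single bromine atom on this aromatic carbon of the fused system has no effect that can be told from the scatter. No supporting evidence bears on this result.

What the compounds shown leave open is whether a different group at this position, such as an amine or a carboxylic acid, would move the number beyond the scatter. They also leave open whether bromo would read the same on the core of compound 1, with its two methoxy groups.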